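Compound 3: methyl in place of methoxy

The source may report more compounds than this note shows. Statements on the series, on what has been measured and on what is new or still open speak of the compounds shown alone.

Among the measured compounds shown here, in a functional assay on HepG2 cells (Homo sapiens) for cytotoxicity, read by CCK-8 assay (on this read-out higher numbers stand for weaker inhibition and lower numbers for stronger inhibition), compound 1 `O=C(Nc1ccc(O)cc1)c1ncc(-c2ccccc2)o1` gives 1270 nM and is the only compound so far with a true number. Compound 2 `COc1ccc(NC(=O)c2ncc(-c3ccccc3)o2)cc1` reads > 30000 nM as a limit of the assay and not a number. Its standing is therefore known only from the limit of > 30000 nM in this assay, at which 1 of the 2 values shown sits, and nothing finer.

Compound 3 `Cc1ccc(NC(=O)c2ncc(-c3ccccc3)o2)cc1` carries methyl in place of methoxy on an aromatic carbon, para to a large group methyl in place of methoxy on an aromatic carbon and has not yet been measured. For the measured compounds named here, one measured step bears on this: methyl in place of hydrogen on an oxygen on an aromatic ring gave an at least 23-fold higher number from compound 1 to compound 2 (1.37 log units; beyond the scatter) as a large move, and compound 3 also lacks that hydrogen. Going by the values given here, no measured step covers the exchange of methoxy itself. Compound 3 is therefore expected to stay close to compound 2 in this assay with no step beyond the scatter and a fair chance of another limit. The expected move is an at least 1.2-fold lower number from compound 2 to compound 3 (0.07 log units; that floor lies within the scatter) in either direction. For compound 3 the estimate is 25000 nM with an expected range from 7000 nM to 60000 nM at the upper end.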

Compound 3, half-maximal inhibitory concentration: > 30000 nM
Compound 3 was reported as a limit; the forecaster's own chance of this, stated with the estimate: 55%; at least 1.2-fold (0.07 log units) between middle value and limit.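

In this assay compound 3 reads > 30000 nM, which is a limit of the assay and not a number. Replacing hydroxy with methyl on the aromatic carbon brings an at least 23-fold higher number from compound 1 to compound 3 (1.37 log units; beyond the scatter), so a second replacement of hydroxy at this place, this time one with no oxygen, also ends without a measurable value, and the loss of a true number is not tied to methoxy alone. The step between the methoxy and methyl compounds cannot be read, and hydroxy remains the only group at this place with a true number, with the rest of the series resting on a single ceiling: the limit of > 30000 nM in this assay, at which 2 of the 3 values shown sit.

The compounds shown do not tell whether the true number of compound 1 depends on the hydrogen of hydroxy or on the oxygen attached to the ring, and an amine at the same place would be the closest test of that question. They also leave open how methoxy and methyl compare with each other, since neither compound has a value beyond its limit.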